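Hydroxy-to-methyl swap on the aryl ring of compound 3

A few compounds are considered here, and "the series" means these few. Any claim that something is new, unique, unknown or untested is made for them only; others in the source may bear on it.

Going by the values given here, compound 3 `CC1(C)[C@H]2CC[C@]1(C)N(Cc1cn(-c3cccc(O)c3)nn1)C(=O)C2` gives 410 nM in a functional assay on LoVo cells (Homo sapiens) for inhibition, read by MTT assay, with a stated time of 24 h (a lower number here means a stronger inhibitor, a higher number a weaker inhibitor), the highest of the three numbers so far; compound 1 `COc1ccc(-n2cc(CN3C(=O)C[C@@H]4CC[C@@]3(C)C4(C)C)nn2)cc1` gives 70 nM and compound 2 `CC1(C)[C@H]2CC[C@]1(C)N(Cc1cn(-c3ccccc3)nn1)C(=O)C2` gives 50 nM in this assay. Compound 4 `Cc1cccc(-n2cc(CN3C(=O)C[C@@H]4CC[C@@]3(C)C4(C)C)nn2)c1` carries the change (methyl in place of hydroxy on an aromatic carbon). The step of an 8.2-fold higher number from compound 2 to compound 3 (0.91 log units; beyond the scatter) bears on it most: the hydroxy that now leaves is the one that entered there. The step of a 1.4-fold lower number from compound 1 to compound 2 (0.15 log units; within the scatter) shows hydrogen and methoxy on that ring within the scatter of each other. Removal of the hydroxy is therefore expected to undo most of the loss; methyl in place of hydrogen has no precedent in the series. The estimated step is a 5.9-fold lower number from compound 3 to compound 4 (0.77 log units; beyond the scatter). Compound 4 is expected at 70 nM, with a range of 30 nM to 200 nM.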

Compound 4, half-maximal inhibitory concentration: 50 nM
Compound 4: middle estimate off by 1.4-fold (0.15 log units), on the high side; measured number inside the range.
By their numbers in this assay, from the lowest: compounds 2, 4 and 1 (each within the scatter of the next); then compound 3.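

Methyl in place of hydroxy on this aromatic carbon gives an 8.2-fold lower number from compound 3 to compound 4 (0.91 log units; beyond the scatter) in this assay, so the hydroxy of compound 3 is set apart from a carbon substituent at the same position. Methyl in place of hydrogen gives no change at the digits printed from compound 2 to compound 4 (within the scatter) and the full aryl change gives a 1.4-fold lower number from compound 1 to compound 4 (0.15 log units; within the scatter), so a methyl here, meta to a large group, is tolerated within the scatter. No measured evidence accounts for the cost of the hydroxy.

As far as these compounds go, whether that cost is particular to hydroxy remains open. An amine or a longer chain such as propyl on this carbon could separate the two readings.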